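Carbamate side chain of the piperazine series: compound 4

The source may hold more compounds than are shown below. What is called first, only, known or untested is meant among the compounds shown, and "the series" means these compounds.

Compound 1 `CCCCCCCC(=O)OCC1CN(C(=O)c2cc(OC)c(OC)c(OC)c2)CCN1C(=O)c1cc(OC)c(OC)c(OC)c1`, compound 2 `COc1cc(C(=O)N2CCN(C(=O)c3cc(OC)c(OC)c(OC)c3)C(COC(=O)C3CCCCC3)C2)cc(OC)c1OC` and compound 3 `COc1cc(C(=O)N2CCN(C(=O)c3cc(OC)c(OC)c(OC)c3)C(COC(=O)NC(C)(C)C)C2)cc(OC)c1OC` share one core and differ only in the acyl group on the side-chain oxygen. In a functional assay (Oryctolagus cuniculus) for inhibition of platelet-activating factor receptor (Cavia porcellus) (a higher number here means a weaker inhibitor, a lower number a stronger inhibitor), compound 1 gives 310 nM, compound 2 gives 290 nM and compound 3 gives 130 nM. Compound 3 thus carries the lowest number of the three; the step of a 2.2-fold lower number from compound 2 to compound 3 (0.35 log units; beyond the scatter) and the step of a 2.4-fold lower number from compound 1 to compound 3 (0.38 log units; beyond the scatter) both lie beyond the scatter, whereas a 1.1-fold lower number from compound 1 to compound 2 (0.03 log units; within the scatter) does not.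

Compound 4 `COc1cc(C(=O)N2CCN(C(=O)c3cc(OC)c(OC)c(OC)c3)C(COC(=O)NCCC(C)C)C2)cc(OC)c1OC` keeps the carbamate of compound 3 and changes only its nitrogen substituent: isopentyl in place of tert-butyl on an amide-type nitrogen. Going by the values given here, no measured pair changes the alkyl on the carbamate nitrogen, so no step bears on it directly. The nearest comparison is the exchange of one acyl alkyl for another on the ester side, a 1.1-fold lower number from compound 1 to compound 2 (0.03 log units; within the scatter), which stayed within the scatter, while the larger steps to compound 3 came from replacing an ester by a carbamate, a feature compound 4 retains. For compound 4 in this assay a step of about a 1.2-fold higher number from compound 3 to compound 4 (0.06 log units; within the scatter) is therefore expected, within the scatter. Compound 4 is estimated at 150 nM, with a range from 70 nM to 330 nM.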

Compound 4, half-maximal inhibitory concentration: 140 nM
Estimate against measurement, compound 4: 1.1-fold (0.03 log units) above; the range from low to high includes it.
By their numbers in this assay, from the lowest: compounds 3 and 4 (each within the scatter of the next); then compounds 2 and 1 (each within the scatter of the next).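

In this assay, going by these compounds alone, the step at the amide-type nitrogen, a 1.1-fold higher number from compound 3 to compound 4 (0.03 log units; within the scatter), stays within the scatter, so the exchange of tert-butyl for isopentyl leaves the number effectively unchanged, the first direct reading of a change at this nitrogen. Compound 4 also repeats the separation from the esters seen with compound 3: a 2.1-fold lower number from compound 2 to compound 4 (0.32 log units; beyond the scatter) and a 2.2-fold lower number from compound 1 to compound 4 (0.35 log units; beyond the scatter) both lie beyond the scatter, so among the compounds shown, the lower numbers belong to both carbamates rather than to compound 3 alone, with no compound going against this. No supporting measurement accounts for either observation.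

The two alkyl groups shown leave open whether the same flat reading extends to other substituents on the carbamate nitrogen, such as a phenyl ring, a longer chain, a terminal amine or a carboxylic acid. Also open, going by these compounds, is how the number responds when the amide hydrogen of the carbamate is replaced by a methyl group, or when the carbamate oxygen is replaced by a nitrogen to give a urea.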